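Swapping the para group on compound 2

A few compounds are considered here, and "the series" means these few. Any claim that something is new, unique, unknown or untested is made for them only; others in the source may bear on it.

Measured so far:
compound 1, `Cc1cc(Nc2nc3nonc3nc2O)ccc1OCC(F)(F)F`, 7000 nM in an assay on mitochondria from L6 cells (Rattus norvegicus) for activation, with a stated time of 90 min; a higher number here means that more compound is needed for the effect, a lower number that less compound is needed
compound 2, `Oc1nc2nonc2nc1Nc1ccc(S(F)(F)(F)(F)F)cc1`, 3900 nM

Compound 2 gives the lower of the two numbers, but compound 1 sits within the scatter of it, so no order between them is claimed. Compound 3, `Oc1nc2nonc2nc1Nc1ccc(OC(F)(F)Cl)cc1`, keeps the core of compound 2 and differs only in the group on the aromatic carbon: a group of 5 heavy atoms (1 carbon, 1 oxygen, 2 fluorine, 1 chlorine; no ring) in place of a group of 6 heavy atoms (5 fluorine, 1 sulfur; no ring), on an aromatic carbon. For the measured compounds named here, with no measured step of this kind to lean on, the step from compound 2 in this assay is expected to stay within the scatter, as a 1.3-fold higher number from compound 2 to compound 3 (0.11 log units; within the scatter). Compound 3 is therefore estimated at 5000 nM, between 1500 nM and 15000 nM.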

Compound 3, half-maximal effective concentration: 1900 nM
Compound 3: middle estimate off by 2.6-fold (0.42 log units), on the high side; low and high end bracket the measured number.
By their numbers in this assay, from the lowest: compound 3; then compounds 2 and 1 (each within the scatter of the next).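

For the compounds shown here, this gives the first step at this aromatic carbon that can be read in this assay, and chloro(difluoro)methoxy in this place gives a 2.1-fold lower number from compound 2 to compound 3 (0.31 log units; beyond the scatter) and so lies beyond the scatter, if modestly. Going by these compounds alone, the group on this carbon can therefore move the number, which compound 1 and compound 2, with no single-place step between them, could not show. Nothing at hand accounts for the step.
As far as these compounds go, whether a methoxy group, a chlorine, an amine or a carboxylic acid on this carbon would hold or shift the number remains open. With one step, no trend across groups can be read.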